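From cyclopentylsulfanyl to (1-(oxan-4-yl)ethyl)amino

The compounds below may be only part of what the source reports. "The series", "measured", "known", "first", "only" and "open" are said of these compounds alone.

In a physicochemical assay for lipophilicity, using the shake flask method, measured as octanol-water partition, at pH 7.4 (on this read-out lower numbers stand for lower lipophilicity and higher numbers for higher lipophilicity), compound 3 `NC(=O)c1cnc2ccc(-c3cccnc3)cc2c1SC1CCCC1` gives 3.2. That lies within the usual scatter of compound 1 `CCC(CC)CNc1c(C(N)=O)cnc2ccc(C#N)cc12` at 3.5 and of compound 2 `C[C@@H](Nc1c(C(N)=O)cnc2ccc(C#N)cc12)c1ccc(Cl)cc1` at 3.5, so these three cannot be ranked. Compound 4 `C[C@@H](Nc1c(C(N)=O)cnc2ccc(-c3cccnc3)cc12)C1CCOCC1` has not yet been measured. It has (1-(oxan-4-yl)ethyl)amino in place of the cyclopentylsulfanyl of compound 3, on an aromatic carbon ((1-(oxan-4-yl)ethyl)amino in place of cyclopentylsulfanyl on an aromatic carbon). The entering group brings a hydrogen-bond donor and a six-membered ring with a hetero atom, whereas the leaving ring is carbon only. Going by the values given here, no measured pair shows this swap, so the expectation rests on the structural change alone. The expected change is a number 0.60 log units lower from compound 3 to compound 4 (beyond the scatter), a drop beyond the scatter. For compound 4 the estimated value is 2.6, with an expected range from 2.1 to 3.1.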

Compound 4, distribution coefficient: 2.3
Beside the measured number, compound 4's estimate is 0.30 log units above it; the range from low to high includes it.
By their numbers in this assay, from the lowest: compound 4; then compounds 3, 1 and 2 (each within the scatter of the next).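

At this aromatic carbon, ortho to a carbamoyl group, (1-(oxan-4-yl)ethyl)amino in place of cyclopentylsulfanyl gives a clear separation in this assay: the step is a number 0.90 log units lower from compound 3 to compound 4 (beyond the scatter). The earlier compounds could not be ranked, so this is the first change shown that moves the number by more than the scatter. Nothing measured here gives a reason for the step.

The swap alters the linking atom and the ring together, leaving open which of them carries the step. A cyclopentylamino group or an oxan-4-ylsulfanyl group at this place would separate the two.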